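Ethoxy in place of amino on the aryl ring

A few compounds are considered here, and "the series" means these few. Any claim that something is new, unique, unknown or untested is made for them only; others in the source may bear on it.

Three analogues of the shared core have been measured in a functional assay (muscle tissue) with Cavia porcellus as the target; a lower number here means that less compound is needed, a higher number that more compound is needed for the effect. Compound 1 `COC(=O)C1=C(C)N=C(C)/C(=C(\O)OC)C1c1ccc(Cl)cc1` gives 8130 nM, compound 2 `COC(=O)C1=C(C)N=C(C)/C(=C(\O)OC)C1c1c(Cl)cccc1Cl` gives 1.91 nM, and compound 3 `COC(=O)C1=C(C)N=C(C)/C(=C(\O)OC)C1c1ccccc1N` gives 39800 nM. Compound 3 thus stands at the highest number of the three: the step of a 4.9-fold higher number from compound 1 to compound 3 (0.69 log units; beyond the scatter) is modest, whereas a 21000-fold higher number from compound 2 to compound 3 (4.32 log units; beyond the scatter) is large, as is a 4300-fold lower number from compound 1 to compound 2 (3.63 log units; beyond the scatter).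

Compound 4 `CCOc1ccccc1C1C(C(=O)OC)=C(C)N=C(C)/C1=C(\O)OC` differs from compound 3 in one place: ethoxy in place of amino on an aromatic carbon. Among the measured compounds shown here, no measured step exchanges one group for another on the same aromatic carbon with the rest unchanged, so the expectation rests on the spread among the three measured aryl rings. The large span seen in a 21000-fold higher number from compound 2 to compound 3 (4.32 log units; beyond the scatter) shows how strongly the substitution of this ring moves the number, and the amino-bearing compound 3 sits at the weak end of it. A large step toward a lower number is therefore expected for a 130-fold lower number from compound 3 to compound 4 (2.12 log units; beyond the scatter). It is not expected to reach the level of compound 2, which gives 1.91 nM. For compound 4 the estimate in this assay is 300 nM, within 30 nM to 3000 nM.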

Compound 4, half-maximal effective concentration: 110 nM
For compound 4 the middle estimate is 2.7-fold (0.44 log units) above the measured one, within the range that was stated.
By their numbers in this assay, from the lowest: compound 2; then compound 4; then compound 1; then compound 3.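

In this assay, ethoxy in place of amino on an aromatic carbon, ortho to a large group, gives a 360-fold lower number from compound 3 to compound 4 (2.56 log units; beyond the scatter), the only step shown that exchanges one group for another at a single aromatic carbon with the rest unchanged. This shows that the identity of this one group can move the number by a large amount, which the comparisons between differently substituted aryl rings could not isolate. The change both removes the hydrogen-bond donor of amino and enters a larger group, and nothing on hand bears on why the number moves.

Methoxy and hydroxy at this carbon, or a longer chain such as propoxy, would help separate group size from the loss of the donor. From the compounds shown here alone, how ethoxy behaves with a chloro group also on the ring remains open.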